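The compounds below may be only part of what the source reports. "The series", "measured", "known", "first", "only" and "open" are said of these compounds alone.

Compound 3 `CCOC(=O)c1cnc(N2CCN(Cc3cccc([N+](=O)[O-])c3)CC2)nc1Oc1c(C)cc(-c2ccc(C#N)cc2)cc1C` is one of three compounds in this set that share the same core and differ only in the group on the benzyl ring attached to the ring amine nitrogen. In an ADME assay on MT4 cells (Homo sapiens) for cytotoxicity, read by MTT assay, with a stated time of 4 days (a higher number here means that more compound is tolerated, a lower number that less compound is tolerated), compound 3 gives > 125000 nM, a limit rather than a number. Compound 1 `CCOC(=O)c1cnc(N2CCN(Cc3ccccc3F)CC2)nc1Oc1c(C)cc(-c2ccc(C#N)cc2)cc1C` gives > 125000 nM in this assay, also a limit. Compound 2 `CCOC(=O)c1cnc(N2CCN(Cc3ccc(C(=O)OC)cc3)CC2)nc1Oc1c(C)cc(-c2ccc(C#N)cc2)cc1C` gives > 125000 nM in this assay, again a limit. All three values rest on (the limit of > 125000 nM in this assay, at which 3 of the 3 values shown sit), so compound 3 stands level with compounds 1 and 2 as far as the numbers go. The change from compound 3 to compound 4 `CCOC(=O)c1cnc(N2CCN(Cc3cccc(C(N)=O)c3)CC2)nc1Oc1c(C)cc(-c2ccc(C#N)cc2)cc1C` is carbamoyl in place of nitro on an aromatic carbon. The measured steps that exchange one benzyl substituent for another are a step that the two limits leave unreadable from compound 1 to compound 2, a step that the two limits leave unreadable from compound 1 to compound 3 and a step that the two limits leave unreadable from compound 2 to compound 3; none of them has a readable size, both ends of each being limits. Going by the values given here, no measured step touches the carbamoyl group itself. Because compounds 1, 2 and 3 all sit at the limit of > 125000 nM in this assay, at which 3 of the 3 values shown sit, compound 4 is expected to follow, and the expected step that the limit leaves unreadable from compound 3 to compound 4 should not reach beyond the scatter. Compound 4 is expected to give 150000 nM in this assay, within 60000 nM to 400000 nM, most likely reported again as a limit.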

Compound 4, half-maximal cytotoxic concentration: 14800 nM
Estimate against measurement, compound 4: 10-fold (1.01 log units) above, and the stated range ends above it.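

In this assay, the group on the benzyl ring now makes a visible difference: carbamoyl in place of nitro on the same aromatic carbon gives an at least 8.4-fold lower number from compound 3 to compound 4 (0.92 log units; beyond the scatter), and this step lies beyond the scatter. Going by these compounds alone, the 3-carbamoylbenzyl group also separates from the two other benzyl groups, with an at least 8.4-fold lower number from compound 2 to compound 4 (0.92 log units; beyond the scatter) and an at least 8.4-fold lower number from compound 1 to compound 4 (0.92 log units; beyond the scatter), whereas the steps among compounds 1, 2 and 3 cannot be read, so the earlier compounds gave no sign that this part of the molecule could shift the read-out. Each of the three new steps is bounded on one side only, and compound 4 is the only compound here with a number rather than a limit: the limit of > 125000 nM in this assay, at which 3 of the 4 values shown sit.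

Whether the lower number goes with the carbamoyl group specifically stays open, as the compounds shown do not tell how an amine, a carboxylic acid or an N-methyl amide on the same aromatic carbon would read. As far as these compounds go, how far compounds 1, 2 and 3 actually lie from compound 4 also stays open, their readings being limits.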